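Cytotoxicity notes on two cores and one substituent swap

The source may report more compounds than this note shows. Statements on the series, on what has been measured and on what is new or still open speak of the compounds shown alone.

Measured so far in a functional assay on MT4 cells (Homo sapiens) for cytotoxicity; on this read-out lower numbers stand for stronger inhibition and higher numbers for weaker inhibition:

compound 1, `Cc1cc(Cl)cc(Sc2cccc(N)c2C#N)c1`, gives 16000 nM
compound 2, `COc1cc(C)cc(Sc2cccc(N)c2C#N)c1`, gives 10000 nM
compound 3, `Cc1cc(Cl)cc(S(=O)(=O)c2cccc(N)c2C#N)c1`, gives > 200000 nM

The value recorded for compound 3 is a limit of this assay and not a number, as the limit of > 200000 nM in this assay, at which 1 of the 3 values shown sits, shows.

Compound 1 and compound 2 share a core and differ in one place: methoxy in place of chloro on an aromatic carbon. This change gives a 1.6-fold lower number from compound 1 to compound 2 (0.20 log units; within the scatter), so the two compounds sit within the scatter of each other and no order is read between them.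

Compound 3 carries a different core from compound 1; the difference between the two cores is not broken down here. Compound 4, `COc1cc(C)cc(S(=O)(=O)c2cccc(N)c2C#N)c1`, is not yet measured and stands to compound 3 exactly as compound 2 stands to compound 1, with the same change made in the same place: methoxy in place of chloro on an aromatic carbon. Among the compounds shown, this change occurs twice in all.

For this assay, the step from compound 3 to compound 4 is expected to be small, a step that the limit leaves unreadable from compound 3 to compound 4, beside the measured 1.6-fold lower number from compound 1 to compound 2 (0.20 log units; within the scatter), which rests on compound 1 and compound 2 alone. Since the value of compound 3 is a limit, compound 4 is also expected to come back as a limit rather than a number in most runs. The estimate for compound 4 is 250000 nM, with a range from 100000 nM to 600000 nM.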

Compound 4, half-maximal inhibitory concentration: 94000 nM
For compound 4 the middle estimate is 2.7-fold (0.42 log units) above the measured one; the whole stated range lies above it.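

Methoxy in place of chloro on an aromatic carbon, made on the second core, gives an at least 2.1-fold lower number from compound 3 to compound 4 (0.32 log units; beyond the scatter) in this assay. On the first core the same change leaves the pair within the scatter, so this series does not show one clear size for the step, and it also does not show that the step depends on the core: the same change on two cores in this assay, a 1.6-fold lower number (0.20 log units; within the scatter) from compound 1 to compound 2 and an at least 2.1-fold lower number (0.32 log units; beyond the scatter) from compound 3 to compound 4; the limit leaves it open whether they differ. The value of compound 3 is a limit of the assay and not a number, so the step on the second core has only a lower bound and its true size may be larger: the limit of > 200000 nM in this assay, at which 1 of the 4 values shown sits.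

With only two pairs carrying this change, nothing shown ties the size of the step to any particular feature of either core, and a rule for carrying the change to a further core cannot be drawn from them. The compounds shown also leave open how this assay would read with other groups at the same aromatic carbon, such as an amine, a carboxylic acid or a longer chain such as butoxy, on either core.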